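The source may hold more compounds than are shown below. What is called first, only, known or untested is meant among the compounds shown, and "the series" means these compounds.

Measured compounds:
- Compound 1 `Cc1ccc(NC(=O)CCc2cccc3c2B(O)OC3)cc1` in an ADME assay on WI-38 cells (Homo sapiens) for cytotoxicity, read by MTT assay, with a stated time of 72 h (a higher number here means a weaker inhibitor, a lower number a stronger inhibitor), is reported only as a limit, > 100000 nM, not as a number.
- Compound 2 `O=C(CCc1cccc2c1B(O)OC2)Nc1ccccc1-c1ccccc1` gives 77000 nM in this assay.
- Compound 3 `O=C(CCc1cccc2c1B(O)OC2)Nc1cccc(-c2ccccc2)c1` gives 12000 nM in this assay.

All three compounds share a core with an amide linked to a phenyl ring; they differ in what sits on that ring. Among the two numbers shown, compound 3 has the lowest, with compound 2 as its nearest neighbour at a clearly higher number, a gap beyond the usual scatter. The value of compound 1 sits at a limit of this assay (the limit of > 100000 nM in this assay, at which 1 of the 3 values shown sits), so it cannot be ranked against the other two.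

The next compound, compound 4 `N#Cc1cccc(-c2cccc(NC(=O)CCc3cccc4c3B(O)OC4)c2)c1`, is not yet measured. It differs from compound 3 in one place: cyano in place of hydrogen on an aromatic carbon. Cut one bond further out, the change reads phenyl to 3-cyanophenyl.

For the measured compounds named here, no measured pair in this set shows what such a change does. The step from compound 3 to compound 4 is therefore expected to be small, a 1.2-fold lower number from compound 3 to compound 4 (0.08 log units; within the scatter), in no direction beyond the scatter. Compound 4 is estimated at 10000 nM in this assay, within a range from 3000 nM to 40000 nM.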

Compound 4, half-maximal inhibitory concentration: 7300 nM
Compound 4: the middle estimate sits 1.4-fold (0.14 log units) above what was measured; the range from low to high includes it.
By their numbers in this assay, from the lowest: compounds 4 and 3 (each within the scatter of the next); then compound 2. At a limit, above all of these: compound 1.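

For the compounds shown here, this is the first pair in the set that differs in only one place, so it gives the first direct look at what a single change on this ring does in this assay: going from phenyl to 3-cyanophenyl gives a 1.6-fold lower number from compound 3 to compound 4 (0.22 log units; within the scatter). At this position, meta to a large group, a cyano group can therefore take the place of hydrogen, adding two heavy atoms and one hydrogen-bond acceptor, with no difference that repeated measurements could separate from the scatter. No measurement shown here bears on what lies behind this step.

One pair cannot show whether this holds for other groups at the same place, so an amine, a carboxylic acid or a methoxy group there remains an open case. It also leaves open what a cyano group would do at another carbon of this ring, and whether a result like this one would carry over to cells other than those used here.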